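Side-Chain Swap on Compound 1: Expected Clearance of Compound 4

The compounds below may be only part of what the source reports. "The series", "measured", "known", "first", "only" and "open" are said of these compounds alone.

Compound 1 `COC(C)(C)[C@@H](O)C(=O)N1[C@H](C(=O)NCc2cc(Cl)ccc2-n2cnnn2)C[C@@H]2C[C@@H]21` gives 40 mL.min-1.g-1
Compound 2 `CC(C)(C)C[C@@H](O)C(=O)N1CC[C@@H]2C[C@@]21C(=O)NCc1cc(Cl)ccc1-n1cnnn1` gives 27 mL.min-1.g-1
Compound 3 `CCCC[C@@H](O)C(=O)N1[C@@H]2C[C@@H]2C[C@H]1C(=O)NCc1cc(Cl)ccc1-n1cnnn1` gives 89 mL.min-1.g-1

Three compounds built on a shared core have been run in an ADME assay on liver for metabolic stability, with Liver microsome (Homo sapiens) as the target, read by LC-MS, using microsomes; a higher number here means faster removal of the compound, a lower number slower removal. Among them compound 1 holds the second highest number. Compound 2 is its nearest neighbour, and the gap between the two lies within the scatter of repeated measurement, so they cannot be ordered. Compound 3 is furthest away, with a higher number, and that gap lies beyond the scatter.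

Compound 4 `CC(C)(C)OC[C@@H](O)C(=O)N1[C@H](C(=O)NCc2cc(Cl)ccc2-n2cnnn2)C[C@@H]2C[C@@H]21` has not yet been measured in this assay. It differs from compound 1 in one place: (tert-butoxy)methyl in place of 1-methoxy-1-methylethyl on a saturated chain carbon bound to a carbonyl carbon and an oxygen on a saturated carbon. Going by the values given here, none of the measured pairs isolates this change, so no measured step can be borrowed. Both groups are short saturated chains of similar make-up, and the expected step is small: a 1.1-fold higher number from compound 1 to compound 4 (0.05 log units; within the scatter) is expected to stay within the scatter, with no clear direction. Compound 4 is therefore estimated at 45 mL.min-1.g-1, with an expected range from 20 mL.min-1.g-1 to 100 mL.min-1.g-1.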

Compound 4, intrinsic clearance in microsomes: 21 mL.min-1.g-1
Estimate against measurement, compound 4: 2.1-fold (0.33 log units) above; measured number inside the range.
By their numbers in this assay, from the lowest: compounds 4, 2 and 1 (each within the scatter of the next); then compound 3.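

In this assay, going by these compounds alone, this is the first step that isolates the saturated chain carbon bound to a carbonyl carbon and an oxygen on a saturated carbon, which the earlier compounds, differing in more than one place, could not do: a 1.9-fold lower number from compound 1 to compound 4 (0.28 log units; within the scatter). Exchanging 1-methoxy-1-methylethyl, with 5 heavy atoms, for (tert-butoxy)methyl, with 6, therefore leaves compound 4 and compound 1 unordered, and this one change at this place does not move the number beyond the scatter. Nothing given here bears on what lies behind this result.

Going by these compounds, whether an amine or a carboxylic acid at the same place would give a step beyond the scatter remains open. So does whether this exchange would give a similar step on the core of compound 2.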